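The source may hold more compounds than are shown below. What is called first, only, known or untested is meant among the compounds shown, and "the series" means these compounds.

Compound 1 `CC(C)Nc1nc(N)nc2c1ncn2/C=C1/CC1(CO)CO` is the starting point of this step. In an ADME assay on MOLT-3 cells (Homo sapiens) for cytotoxicity, with a stated time of 7 days (on this read-out lower numbers stand for higher toxicity in this test and higher numbers for lower toxicity in this test), compound 1 gives "not determined" (no result reported), so no number places it on the scale. Two related compounds have been measured. Compound 2 `Nc1nc2c(ncn2/C=C2/CC2(CO)CO)c(=O)[nH]1` gives in this assay a reading of > 20000 nM, which is a limit of the assay rather than a number. Compound 3 `CCCCCCSc1nc(N)nc2c1ncn2/C=C1/CC1(CO)CO` likewise gives in this assay a reading of > 20000 nM, again a limit. Both of these results sit at the limit of > 20000 nM in this assay, at which 2 of the 3 values shown sit.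

The new compound, compound 4 `Nc1nc(SC2CCCC2)c2ncn(/C=C3/CC3(CO)CO)c2n1`, differs from compound 1 in one place: cyclopentylsulfanyl in place of isopropylamino on an aromatic carbon. Among the measured compounds shown here, no step between measured compounds is available, so the size of the change from compound 1 to compound 4 in this assay cannot be read from a measured pair. No shift beyond the usual scatter toward stronger toxicity is expected because compound 3 sits at the limit of > 20000 nM in this assay, at which 2 of the 3 values shown sit. Compound 4 is therefore expected to give 20000 nM in this assay, within an estimated range of 8000 nM to 40000 nM.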

Compound 4, half-maximal cytotoxic concentration: > 20000 nM
Compound 4: only a limit was reported; the forecaster's own chance of this, stated with the estimate: 75%; the middle value sits exactly at the limit.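

Among the compounds shown here, compound 3 and compound 4 both give a limit rather than a number in this assay, and compound 1 has no reported result, so no step to compound 4 can be read. The compounds shown leave open whether cyclopentyl in place of hexyl on the sulfur alters toxicity in this test.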